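This account rests on a few compounds, and the source may have more. Where it says the series, first, only, none or still open, it means among the compounds named here.

The measured compounds and their values in a physicochemical assay for lipophilicity, using the shake flask method, at pH 7.4; on this read-out higher numbers stand for higher lipophilicity and lower numbers for lower lipophilicity:

Compound 1, `CCCC(Nc1cc(C)c(-n2cc(C(F)(F)F)cn2)c(C)c1)c1ccc(C(=O)NCCC(=O)O)cc1`, gives 2.2.
Compound 2, `CCCC(Oc1ccc(-n2cccn2)cc1)c1ccc(C(=O)NCCC(=O)O)cc1`, gives 1.7.
Compound 3, `CCCC(Nc1cnc(-n2cc(C(F)(F)F)cn2)nc1)c1ccc(C(=O)NCCC(=O)O)cc1`, gives 1.3.

Among these three, compound 2 stands second highest in this assay. Its nearest neighbour is compound 3, whose value lies lower by a gap beyond the usual scatter of the measurement, while compound 1 is furthest away, higher than compound 2 by a gap that is also beyond the scatter. Among the measured compounds shown here, none of these three compounds differs from another in only one place, so no single-change step between measured compounds can be read off here.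

The unmeasured compound 4, `CCCC(Oc1ccc(-n2cc(C)cn2)cc1)c1ccc(C(=O)NCCC(=O)O)cc1`, is the one this account follows. It departs from compound 2 in a single place: methyl in place of hydrogen on an aromatic carbon. For the measured compounds named here, no measured pair shows the effect of this exact change. On the basis of the values of compounds 1, 2 and 3 alone, a modest rise in this assay is expected for compound 4, of the order of a number 0.40 log units higher from compound 2 to compound 4 (beyond the scatter), since the change adds one carbon and no donor or acceptor. The estimated value for compound 4 in this assay is 2.1, with a range from 1.8 to 2.4.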

Compound 4, distribution coefficient: 2.1
Compound 4: middle estimate and measured number agree at the digits printed; the measured number falls inside the stated range.
By their numbers in this assay, from the lowest: compound 3; then compound 2; then compounds 4 and 1 (each within the scatter of the next).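

In this assay, among the compounds shown here, the swap of 1H-pyrazol-1-yl for 4-methyl-1H-pyrazol-1-yl gives a number 0.40 log units higher from compound 2 to compound 4 (beyond the scatter), and this is the first change in a single place whose size can be read. The earlier compounds shown here differ from one another in more than one place, so they could show only a spread of values, whereas this step ties a modest rise to one site: an aromatic carbon of the five-membered aromatic ring with 2 nitrogen, two ring bonds from the ring nitrogen. Nothing at hand accounts for the size of this step, which therefore stands as an observation for this pair alone.

The compounds shown leave open whether a nitrile, an ethyl or a hydroxymethyl group on the same carbon would move the number in the same direction, or by a similar amount. For the compounds shown here, they also leave open whether methyl in place of hydrogen would give a comparable step on another aromatic carbon, or on a core other than the one shared by this pair.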